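Adding a Chloro Group to Compound 2

The source may hold more compounds than are shown below. What is called first, only, known or untested is meant among the compounds shown, and "the series" means these compounds.

- Compound 1 `Cn1cc(C2=C(c3nn(CCCn4cncn4)c4ncccc34)C(=O)N(c3ccccc3)C2=O)c2ccccc21` gives > 100000 nM (a limit of the assay, not a number)
- Compound 2 `Cn1cc(C2=C(c3nn(CCCN4CCCCC4)c4ncccc34)C(=O)N(c3ccccc3)C2=O)c2ccccc21` gives 20600 nM

Among the compounds with values here, in a functional assay on A549 cells (Homo sapiens) for antiproliferative activity, read by MTT assay, with a stated time of 48 h (a higher number here means a weaker inhibitor, a lower number a stronger inhibitor), compound 2 gives 20600 nM, the only true number so far. Compound 1 stands at a limit and has no exact number, as the limit of > 100000 nM in this assay, at which 1 of the 2 values shown sits, records.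

Compound 3 `Cn1cc(C2=C(c3nn(CCCN4CCCCC4)c4ncccc34)C(=O)N(c3ccc(Cl)cc3)C2=O)c2ccccc21` is compound 2 with one change, phenyl to 4-chlorophenyl: chloro in place of hydrogen on an aromatic carbon.

Within the data shown here, only one measured step exists, and it lies elsewhere in the molecule. It is an at least 4.8-fold lower number from compound 1 to compound 2 (0.68 log units; beyond the scatter), with piperidin-1-yl in place of 1H-1,2,4-triazol-1-yl on a saturated chain carbon. That step shows that the numbers in this assay can move within this small set, but it gives no size for a change on the phenyl ring. With no direct guide, a small step is expected, leaning towards a lower number and probably not clearly beyond the scatter. The expected step is a 1.5-fold lower number from compound 2 to compound 3 (0.17 log units; within the scatter). Compound 3 is expected at 14000 nM, with an estimated range from 5000 nM to 40000 nM.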

Compound 3, half-maximal inhibitory concentration: 28700 nM
For compound 3 the middle estimate is 2.1-fold (0.31 log units) below the measured one; the range from low to high includes it.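

In this assay, the change from phenyl to 4-chlorophenyl gives a 1.4-fold higher number from compound 2 to compound 3 (0.14 log units; within the scatter), so this assay does not tell compound 2 and compound 3 apart. Within the data shown here, this is the first information about the phenyl ring, since the earlier step changed only the group at the end of the saturated chain: a single chloro in place of hydrogen on this aromatic carbon, para to a large group, leaves the number within the usual scatter. Among these compounds, that is one substitution at one place, so it shows that this particular change is tolerated without a clear shift, not that the ring as a whole is insensitive, and nothing measured so far offers an explanation for the result.

Still open, going by these compounds, is whether a larger or very different group at the same place, such as methoxy, an amine or a carboxylic acid, would leave the number just as close to that of compound 2. Also open, on these data alone, is whether chloro on another carbon of the ring, or a pyridine ring in place of the phenyl, would shift the number beyond the scatter.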